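This account rests on a few compounds, and the source may have more. Where it says the series, first, only, none or still open, it means among the compounds named here.

Compound 1 `O=C1NCCN1c1ccc(S(=O)(=O)Nc2ccc(I)cc2)cc1`: 600 nM
Compound 2 `O=C1NCCN1c1ccc(S(=O)(=O)Nc2ccc(OC(F)F)cc2)cc1`: 760 nM

In a functional assay on MCF7 cells (Homo sapiens) for antiproliferative activity, read by sulforhodamine B assay, with a stated time of 48 h (on this read-out lower numbers stand for stronger inhibition and higher numbers for weaker inhibition), compound 2 gives 760 nM, level with compound 1 within the usual scatter. Compound 3 `CCCCOc1ccc(NS(=O)(=O)c2ccc(N3CCNC3=O)cc2)cc1` differs from compound 2 as follows: butyl in place of difluoromethyl on an oxygen on an aromatic ring. Within the data shown here, only one measured step bears on this, a 1.3-fold higher number from compound 1 to compound 2 (0.10 log units; within the scatter), and it swapped iodo for difluoromethoxy. Among the measured compounds shown here, no measured compound carries butyl, so this is weak guidance. The expected change is therefore a 1.2-fold lower number from compound 2 to compound 3 (0.07 log units; within the scatter), nothing beyond the scatter. For compound 3 the estimate is 650 nM, with an expected range of 200 nM to 2000 nM.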

Compound 3, half-maximal inhibitory concentration: 870 nM
For compound 3 the middle estimate is 1.3-fold (0.13 log units) below the measured one, within the range that was stated.
By their numbers in this assay, from the lowest: compounds 1, 2 and 3 (each within the scatter of the next).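

In this assay, the change from difluoromethoxy to butoxy gives a 1.1-fold higher number from compound 2 to compound 3 (0.06 log units; within the scatter) and the change from iodo to butoxy gives a 1.5-fold higher number from compound 1 to compound 3 (0.16 log units; within the scatter), so neither step separates the compounds. Butyl on this oxygen therefore reads the same as difluoromethyl, and the position accepts an unfluorinated alkyl chain with no measurable change. No measurement available here explains this flat result. On these data alone, it remains open whether a chain longer than butyl would shift the number, or whether an amine or a carboxylic acid at this position would.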